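The compounds below may be only part of what the source reports. "The series", "measured", "known", "first", "only" and "open" are said of these compounds alone.

Compound 1 `O=c1c2cnn(-c3ccc(F)cc3)c2ncn1CC1(O)CCN(Cc2ccccc2F)CC1` — 9800 nM
Compound 2 `O=c1c2cnn(-c3ccc(F)cc3)c2ncn1CC1(O)CCN(Cc2ccc(F)cc2Cl)CC1` — 1600 nM

Among the compounds with values here, in an assay on Sf21 cells for inhibition of ubiquitin carboxyl-terminal hydrolase 7 (Homo sapiens), read by spectrophotometry, with stated times of 30 min and 2 h (a higher number here means a weaker inhibitor, a lower number a stronger inhibitor), compound 2 stands at the lowest of the two numbers, and the only other compound sits higher by a 6.1-fold lower number from compound 1 to compound 2 (0.79 log units; beyond the scatter). Compound 3 `COC(=O)c1ccc(CN2CCC(O)(Cn3cnc4c(cnn4-c4ccc(F)cc4)c3=O)CC2)c(Br)c1` differs from compound 2 in one place: 2-bromo-4-(methoxycarbonyl)phenyl in place of 2-chloro-4-fluorophenyl on a saturated chain carbon bound to an amine nitrogen in a ring. Within the data shown here, the single measured step bears on this only insofar as it also varied the aryl ring on a saturated chain carbon bound to an amine nitrogen in a ring, and it was modest. Among the measured compounds shown here, no measured compound carries bromine or methoxycarbonyl there, so the direction is open. The step is expected to be small, a 1.1-fold lower number from compound 2 to compound 3 (0.03 log units; within the scatter). Compound 3 is therefore estimated at 1500 nM, in a range of 400 nM to 6000 nM.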

Compound 3, half-maximal inhibitory concentration: 900 nM
Beside the measured number, compound 3's estimate is 1.7-fold (0.22 log units) above it; measured number inside the range.
By their numbers in this assay, from the lowest: compounds 3 and 2 (each within the scatter of the next); then compound 1.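

In this assay the step to the larger 2-bromo-4-(methoxycarbonyl)phenyl on a saturated chain carbon bound to an amine nitrogen in a ring is a 1.8-fold lower number from compound 2 to compound 3 (0.25 log units; within the scatter) and so shows that this place accepts the group. Set against 2-fluorophenyl, the same group gives an 11-fold lower number from compound 1 to compound 3 (1.04 log units; beyond the scatter) and is a large step. Nothing available here explains either step. As far as these compounds go, the bromine and the methoxycarbonyl entered together, so the share of each stays open. Also open, from the compounds shown here alone, is how a carboxylic acid or an amine would read in place of the methoxycarbonyl.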